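Adding chloro to the five-membered ring of compound 2

The compounds below may be only part of what the source reports. "The series", "measured", "known", "first", "only" and "open" are said of these compounds alone.

Measured so far:
compound 1, `O=S(=O)(Nc1cccc2cc[nH]c12)c1ccc(Cl)cc1`, 6 ug/mL
compound 2, `N#Cc1ccc(S(=O)(=O)Nc2cccc3cc[nH]c23)cc1`, 8.5 ug/mL

In a functional assay on KB cells (nasopharynx, Homo sapiens) for antiproliferative activity (on this read-out lower numbers stand for stronger inhibition and higher numbers for weaker inhibition), compound 1 gives 6 ug/mL. For the measured compounds named here, compound 2 gives 8.5 ug/mL in this assay, and the single measured step, a 1.4-fold higher number from compound 1 to compound 2 (0.15 log units; within the scatter), puts the two within the scatter of each other, so compound 2 cannot be told apart from compound 1 on these numbers.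

Compound 3, `N#Cc1ccc(S(=O)(=O)Nc2cccc3c(Cl)c[nH]c23)cc1`, is yet to be tested. It differs from compound 2 by chloro in place of hydrogen on an aromatic carbon. Going by the values given here, no measured step touches this kind of change: the only step seen exchanges groups on the other aromatic ring, and it was itself within the scatter. The step from compound 2 is therefore expected to be small, a 1.1-fold lower number from compound 2 to compound 3 (0.03 log units; within the scatter), with no direction favoured. On that basis compound 3 is estimated at 8 ug/mL in this assay, most likely between 3 ug/mL and 22 ug/mL.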

Compound 3, half-maximal inhibitory concentration: 11 ug/mL
Beside the measured number, compound 3's estimate is 1.4-fold (0.14 log units) below it; low and high end bracket the measured number.
By their numbers in this assay, from the lowest: compounds 1, 2 and 3 (each within the scatter of the next).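

In this assay, chloro in place of hydrogen on an aromatic carbon of the five-membered aromatic ring, two ring bonds from the ring nitrogen, gives a 1.3-fold higher number from compound 2 to compound 3 (0.11 log units; within the scatter) and so is not separated from the scatter. For the compounds shown here, this is the first measured change on the five-membered ring, since the earlier step lay on the other aromatic ring, and a change at either place has so far stayed within the scatter. No available evidence bears on this result.

On these data alone, whether a different group on this carbon, such as an amine or a carboxylic acid, would give a step beyond the scatter remains open. Also open, as far as these compounds go, is whether chloro on this carbon would give a similar step on compound 1, which has chloro in place of cyano on the other aromatic ring.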